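Bromo to chloro on the pendant aryl of compound 3

The compounds below may be only part of what the source reports. "The series", "measured", "known", "first", "only" and "open" are said of these compounds alone.

Compound 3 `O=C(O)c1cc(-n2c(-c3ccc(Br)cc3)cc3c2CCCC3)ccc1O` gives 40% in a functional assay on the whole organism (strain Wistar) for inhibition, with Rattus norvegicus as the target, read by paw edema, with stated times of 30 min and 3 h, at a dose of 200 mg/kg by the oral route (on this read-out higher numbers stand for more inhibition at the one dose given (going by the name of the read-out) and lower numbers for less inhibition), the second highest of the three numbers measured. Its neighbours are compound 1 `COc1ccccc1-c1cc2c(n1-c1ccc(O)c(C(=O)O)c1)CCCC2`, which in this assay gives 50%, and compound 2 `Cc1ccc(-c2cc3c(n2-c2ccc(O)c(C(=O)O)c2)CCCC3)cc1`, which gives 30%. The step of a number 10 percentage points lower from compound 1 to compound 3 (within the scatter) and the step of a number 10 percentage points higher from compound 2 to compound 3 (within the scatter) are both within the scatter, so compound 3 cannot be ordered against either of them; only a number 20 percentage points lower from compound 1 to compound 2 (beyond the scatter) is a step beyond the scatter, and it joins two compounds that each differ from compound 3.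

Compound 4 `O=C(O)c1cc(-n2c(-c3ccc(Cl)cc3)cc3c2CCCC3)ccc1O` differs from compound 3 by chloro in place of bromo on an aromatic carbon. The step that bears most directly on this is the exchange at the same position between compound 2 and compound 3, where one halogen-sized or methyl-sized group replaced another and a number 10 percentage points higher from compound 2 to compound 3 (within the scatter) stayed within the scatter. Within the data shown here, no chloro analogue has been measured anywhere, so the expectation rests on that single step alone.

Accordingly the step of no change at the digits printed from compound 3 to compound 4 (within the scatter) is expected to stay within the scatter, with no clear direction. Compound 4 is estimated at 40% in this assay, in a range from 25% to 55%.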

Compound 4, a percentage reported as inhibition, in the whole organism at one dose (the size of the read-out at that dose, not a potency): 40%
Beside the measured number, compound 4's estimate shows no gap at the digits printed, within the range that was stated.
By their numbers in this assay, from the lowest: compounds 2, 3, 4 and 1 (each within the scatter of the next, the first and the last beyond it).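

In this assay, among these compounds, chloro in place of bromo, para to a large group on the six-membered aromatic ring, gives no change at the digits printed from compound 3 to compound 4 (within the scatter); this is the only exchange of one halogen for another so far. The other two new steps read a number 10 percentage points higher from compound 2 to compound 4 (within the scatter) and a number 10 percentage points lower from compound 1 to compound 4 (within the scatter), so the chloro compound cannot be ordered against either neighbour, exactly as the bromo compound could not, and the two halogens are indistinguishable here. No measured property is available to account for these steps.

Open, from the compounds shown here alone, is whether a different group at this place, such as fluoro, a nitrile or an amine, would stay within the scatter of compound 3 or move beyond it. The read-out at a single dose also leaves open whether compound 3 and compound 4 would still match in potency.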